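A few compounds are considered here, and "the series" means these few. Any claim that something is new, unique, unknown or untested is made for them only; others in the source may bear on it.

Measured so far in an ADME assay on HEL cells (Homo sapiens) for cytotoxicity; on this read-out lower numbers stand for higher toxicity in this test and higher numbers for lower toxicity in this test:

compound 1 `CCN(CC)CN1C(=O)/C(=N/NC(=S)Nc2ccc(OC)cc2)c2ccccc21` — 100000 nM
compound 2 `CCN(CC)CN1C(=O)/C(=N/NC(=S)Nc2ccc(OC)cc2)c2cc(Cl)ccc21` — 100000 nM

Compound 1 stands level with compound 2 on the numbers shown; the step of no change at the digits printed from compound 1 to compound 2 (within the scatter) carries a chloro in place of hydrogen on an aromatic carbon and changes nothing beyond the scatter. Among the compounds with values here, nothing else is measured, so there is no second step to set against this one.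

Compound 3 `CCN(CC)CN1C(=O)/C(=N/NC(N)=S)c2ccccc21` is the next member. Relative to compound 1 it carries hydrogen in place of 4-methoxyphenyl on an amide-type nitrogen: the 4-methoxyphenyl leaves and a hydrogen enters on the amide-type nitrogen next to the thiocarbonyl carbon. Within the data shown here, no measured step touches this nitrogen; the only step in hand, from compound 1 to compound 2, alters an aromatic carbon of the shared core and bears on the present change only as a sign that a single substituent swap elsewhere in the molecule left this assay flat. On that basis no step beyond the scatter is expected in this assay, in either direction, though the change is larger than any measured one and the expectation rests on a single comparison.

Compound 3 is therefore estimated at 100000 nM (range 50000 nM to 200000 nM), the expected step from compound 1 being no change at the digits printed from compound 1 to compound 3 (within the scatter).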

Compound 3, minimum cytotoxic concentration: > 100000 nM
Compound 3: a limit, no number (the forecaster's own chance of this, stated with the estimate: 60%); the middle value sits exactly at the limit.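

In this assay compound 3 gives > 100000 nM, which is a limit of the assay and not a number. Within the data shown here, on the amide-type nitrogen next to the thiocarbonyl carbon, the step reads a number no lower from compound 1 to compound 3 (the limit leaves the size open), so losing the 4-methoxyphenyl with its six-membered aromatic ring does not bring this assay to a lower number, a first reading at this position, since the earlier pair differed only on an aromatic carbon of the shared core. The size of this step cannot be read, and the read-out gives no way of telling how far compound 3 lies from compound 1: the limit of > 100000 nM in this assay, at which 1 of the 3 values shown sits.

On these data alone, whether another group on this nitrogen, such as a methyl, a longer alkyl chain or a phenyl carrying a nitro group, would bring this assay to a lower number remains open. Also open, as far as these compounds go, is what a morpholine in place of the diethylamino group would do, as is whether the chloro on the shared core would stay without effect once the 4-methoxyphenyl has gone.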